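Anilide Sulfonamides on Colon Cancer Cells: From Fluorine to Methoxy

This account rests on a few compounds, and the source may have more. Where it says the series, first, only, none or still open, it means among the compounds named here.

The series shares one core, a thioester-bearing ketone joined to an anilide that carries an aryl sulfonyl group on its nitrogen. Compound 1 `CC(=O)SCC(=O)c1ccc(NS(=O)(=O)c2ccc(Cl)cc2)cc1` bears a 4-chlorophenyl group on that sulfonyl sulfur, and in a functional assay on HCT-116 cells (Homo sapiens) for cytotoxicity (on this read-out lower numbers stand for an effect already at smaller amounts and higher numbers for an effect only at larger amounts of compound), compound 1 gives 30800 nM. Compound 2 `CC(=O)SCC(=O)c1ccc(NS(=O)(=O)c2cccc(F)c2)cc1` carries a 3-fluorophenyl group in the same place, and in this assay compound 2 gives "not determined" (no result reported). Compound 3 `CC(=O)SCC(=O)c1ccc(NS(=O)(=O)c2ccc(F)cc2)cc1` carries a 4-fluorophenyl group there, and in this assay compound 3 gives "not determined" (no result reported). For neither of these two was a result reported in this assay, so compound 3 stands without a number, and the only measured anchor of the set is compound 1.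

Compound 4 `COc1cccc(S(=O)(=O)Nc2ccc(C(=O)CSC(C)=O)cc2)c1` differs from compound 3 in one place: 3-methoxyphenyl in place of 4-fluorophenyl on a sulfonyl sulfur. Going by the values given here, no step between two measured compounds is available, so nothing in the data shows how this kind of swap moves the read-out. Among the compounds with values here, with the single number of compound 1 as the only guide, the step from compound 3 to compound 4 in this assay is expected to be small, none beyond the usual scatter, and in no clear direction.

Compound 4 is therefore estimated to give about 30000 nM in this assay, with a range from 8000 nM to 120000 nM.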

Compound 4, half-maximal effective concentration: 2600 nM
Compound 4: the middle estimate sits 12-fold (1.06 log units) above what was measured, and the stated range ends above it.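

In this assay, the aryl group on the sulfonyl sulfur proves able to move the read-out on its own: with the shared core unchanged, 3-methoxyphenyl in place of 4-chlorophenyl gives a 12-fold lower number from compound 1 to compound 4 (1.07 log units; beyond the scatter), the first step available in this series. The steps that involve compound 2 or compound 3 cannot be read, as neither has a number, so this single pair is all that shows how the place responds, and it says nothing about how the 3-methoxyphenyl group compares with either fluorophenyl group. Nothing in the data shown accounts for the size or direction of this step.

The group and its place on the ring change together in this pair, so the compounds shown do not separate the effect of the methoxy group from that of its place, and a 4-methoxyphenyl or a 3-chlorophenyl group would be needed to tell the two apart. Also open, as far as these compounds go, is how the read-out would respond to a 3-aminophenyl group or to a 3-ethoxyphenyl group, which has a longer chain on the oxygen.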